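Methyl for bromo, ortho to a large group, in compound 2

A few compounds are considered here, and "the series" means these few. Any claim that something is new, unique, unknown or untested is made for them only; others in the source may bear on it.

Measured so far:
compound 1 `O=c1c2ccccc2[se]n1-c1nnc(-c2cccc([N+](=O)[O-])c2)s1` — 16100 nM
compound 2 `O=c1c2ccccc2[se]n1-c1nnc(-c2ccccc2Br)s1` — 12700 nM
compound 3 `COc1ccc(-c2nnc(-n3[se]c4ccccc4c3=O)s2)cc1` — 5930 nM

All three were run in a functional assay on A549 cells (Homo sapiens) for antiproliferative activity, read by CCK-8 assay, with a stated time of 48 h; a lower number here means a stronger inhibitor, a higher number a weaker inhibitor. Compound 2 gives the second highest number of the three; compound 1 lies within the scatter of it, while compound 3 gives a lower number, beyond the scatter. Compound 4 `Cc1ccccc1-c1nnc(-n2[se]c3ccccc3c2=O)s1` has not been measured. It differs from compound 2 by methyl in place of bromo on an aromatic carbon, the same difference read one bond further out being 2-bromophenyl to 2-methylphenyl. Among the measured compounds shown here, no measured pair shows this change, so no step size is known from the set; a single heavy atom traded for a single heavy atom is expected to move the number no further than the scatter, in either direction. Compound 4 is therefore expected at 10000 nM, between 4500 nM and 22000 nM, a step of a 1.3-fold lower number from compound 2 to compound 4 (0.10 log units; within the scatter) that is expected to stay within the scatter.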

Compound 4, half-maximal inhibitory concentration: 18600 nM
Beside the measured number, compound 4's estimate is 1.9-fold (0.27 log units) below it, and the stated range covers the measured number.
By their numbers in this assay, from the lowest: compound 3; then compounds 2, 1 and 4 (each within the scatter of the next).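

In this assay the first pair differing in one place gives a 1.5-fold higher number from compound 2 to compound 4 (0.17 log units; within the scatter), so on this aromatic carbon, ortho to a large group, bromo and methyl cannot be told apart. The series therefore has its first step size at this position, and a halogen is not required there for a number in this range. Nothing available explains the result.

Going by these compounds, whether an amine, a carboxylic acid or a longer chain on this carbon would move the number beyond the scatter remains open. So does whether the same exchange behaves alike elsewhere on the phenyl ring.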